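The source may hold more compounds than are shown below. What is called first, only, known or untested is meant among the compounds shown, and "the series" means these compounds.

Of the compounds shown here, three have been measured in an ADME assay on MDCK cells (Canis lupus familiaris) for cytotoxicity, read by microscopy, with a stated time of 72 h; a higher number here means that more compound is tolerated, a lower number that less compound is tolerated. Compound 1 `COC(=O)C[C@H](NC(=O)OC(C)(C)C)C(=O)N(Cc1ccc(F)cc1)C1(C(=O)NCc2ccccc2)CCNCC1` gives 100000 nM. Compound 2 `COC(=O)C[C@H](NC(=O)OC(C)(C)C)C(=O)N(Cc1ccc(F)cc1)C1(C(=O)NC(C)(C)C)CCN(Cc2ccccc2)CC1` gives 80000 nM. Compound 3 `COC(=O)C[C@H](NC(=O)OC(C)(C)C)C(=O)N(C)C1(C(=O)NCc2ccccc2)CCN(Cc2ccccc2)CC1` gives 20000 nM, the lowest of the three numbers; compound 2 stands nearest to it and compound 1 furthest, both beyond the scatter. Compound 4 `COC(=O)C[C@H](NC(=O)OC(C)(C)C)C(=O)N(Cc1ccc([N+](=O)[O-])cc1)C1(C(=O)NCc2ccccc2)CCN(Cc2ccccc2)CC1` has not yet been measured in this assay. It differs from compound 3 in one place: 4-nitrophenyl in place of hydrogen on a saturated chain carbon bound to an amide-type nitrogen. Among the compounds with values here, no step between measured compounds is available to set the size of this change directly. On the numbers shown, compound 1 and compound 2 both stand beyond the scatter above compound 3. The step from compound 3 to compound 4 is therefore expected to be a moderate rise, a 2.5-fold higher number from compound 3 to compound 4 (0.40 log units; beyond the scatter). Compound 4 is estimated to give 50000 nM, within a range from 15000 nM to 150000 nM.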

Compound 4, minimum cytotoxic concentration: 20000 nM
Beside the measured number, compound 4's estimate is 2.5-fold (0.40 log units) above it, and the stated range covers the measured number.
By their numbers in this assay, from the lowest: compounds 3 and 4 (each within the scatter of the next); then compounds 2 and 1 (each within the scatter of the next).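

In this assay, within the data shown here, 4-nitrophenyl in place of hydrogen on a saturated chain carbon bound to an amide-type nitrogen gives no change at the digits printed from compound 3 to compound 4 (within the scatter), the only step read directly at this position. With the same difference read as methyl to 4-nitrobenzyl, the two groups cannot be told apart in this read-out on this core. No measurement shown accounts for this result. From the compounds shown here alone, whether an amine or a carboxylic acid in place of the nitro group would read the same remains open, as does the effect of a longer chain in place of the 4-nitrobenzyl.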